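Aryl urea series: single-concentration cell inhibition, compound 4

The source may report more compounds than this note shows. Statements on the series, on what has been measured and on what is new or still open speak of the compounds shown alone.

Measured compounds:
compound 1 `COc1cc(NC(=O)Nc2cc(Nc3ccc(C)c(C)c3)ncn2)cc(OC)c1` 20.1%
compound 2 `COc1cc(NC(=O)Nc2cc(Nc3cccc(C(C)(C)C)c3)ncn2)cc(OC)c1` 35.1%
compound 3 `CCc1cccc(Nc2cc(NC(=O)Nc3cc(OC)cc(OC)c3)ncn2)c1` 27.7%

In a functional assay on NCI-H1581 cells (Homo sapiens) for inhibition, read by MTT assay, with a stated time of 48 h, tested at 10 uM (on this read-out lower numbers stand for less inhibition and higher numbers for more inhibition at the one concentration tested (going by the name of the read-out)), the three measured compounds span a narrow band. Compound 3 stands second of the three: its nearest neighbour is compound 2, and the step of a number 7.4 percentage points lower from compound 2 to compound 3 (within the scatter) lies within the scatter, as does the step of a number 7.6 percentage points higher from compound 1 to compound 3 (within the scatter) from its furthest neighbour. Within the data shown here, the only step beyond the scatter is a number 15 percentage points higher from compound 1 to compound 2 (beyond the scatter).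

Compound 4 `COc1cc(NC(=O)Nc2cc(Nc3cc(Br)ccc3OC)ncn2)cc(OC)c1` differs from compound 3 in the group carried by the nitrogen on the aromatic ring: 5-bromo-2-methoxyphenyl in place of 3-ethylphenyl on a nitrogen on an aromatic ring. Among the measured compounds shown here, no measured step changes the aryl group to one bearing a bromine or a methoxy group, so none bears directly on this change. What the measured steps show is that swapping one aryl group for another within this series moves this assay by at most a number 15 percentage points higher from compound 1 to compound 2 (beyond the scatter) and otherwise within the scatter. The step of a number 0.7 percentage points lower from compound 3 to compound 4 (within the scatter) is therefore expected to stay within the scatter, with no clear direction. Compound 4 is estimated at 27%, between 10% and 45%.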

Compound 4, a percentage reported as inhibition, at one concentration (the size of the read-out at that concentration, not a potency): 23.1%
Estimate against measurement, compound 4: 3.9 percentage points above; the range from low to high includes it.
By their numbers in this assay, from the lowest: compounds 1, 4, 3 and 2 (each within the scatter of the next, the first and the last beyond it).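

In this assay, an aryl group carrying a bromine and a methoxy group on the nitrogen reads level with the 3-ethylphenyl and 3,4-dimethylphenyl groups, with a number 4.6 percentage points lower from compound 3 to compound 4 (within the scatter) and a number 3 percentage points higher from compound 1 to compound 4 (within the scatter). The 3-(tert-butyl)phenyl group remains apart from it, with a number 12 percentage points lower from compound 2 to compound 4 (beyond the scatter), a modest step that joins a number 15 percentage points higher from compound 1 to compound 2 (beyond the scatter), though 3-(tert-butyl)phenyl stays within the scatter of 3-ethylphenyl. No measurement offered here explains these numbers.

The compounds shown do not separate the bromine from the methoxy group, as the two occur only together in 5-bromo-2-methoxyphenyl. Also open, from the compounds shown here alone, is whether an amine or a carboxylic acid on this aryl group would move this assay outside the narrow band seen so far.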